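Replacing the 4-methylpiperazin-1-yl group of compound 1

The compounds below may be only part of what the source reports. "The series", "measured", "known", "first", "only" and "open" are said of these compounds alone.

Within the data shown here, in a functional assay on MGC-803 cells (Homo sapiens) for inhibition, read by CCK-8 assay, with a stated time of 48 h (a lower number here means a stronger inhibitor, a higher number a weaker inhibitor), compound 1 `COc1ccc(CN(C(=O)CSC(=S)N2CCN(C)CC2)c2cc(OC)c(OC)c(OC)c2)cc1` gives 1280 nM, the only true number so far. Compound 2 `COc1ccc(CN(C(=O)CSC(=S)N2CCc3cc(Br)ccc32)c2cc(OC)c(OC)c(OC)c2)cc1` reads > 20000 nM, which is a limit of the assay and not a number. Compound 3 `COc1ccc(CN(C(=O)CSC(=S)N2CCc3cc(OC)ccc32)c2cc(OC)c(OC)c(OC)c2)cc1` has not yet been measured. It carries 5-methoxy-2,3-dihydro-1H-indol-1-yl in place of 4-methylpiperazin-1-yl on a thiocarbonyl carbon. Among the measured compounds shown here, the one measured step that bears on this swap is an at least 15-fold higher number from compound 1 to compound 2 (1.19 log units; beyond the scatter), with 5-bromo-2,3-dihydro-1H-indol-1-yl entering at that same carbon. On that single example, a large move towards a higher number, meaning a weaker inhibitor, is expected in this assay. The expected step is a 7.8-fold higher number from compound 1 to compound 3 (0.89 log units; beyond the scatter). Compound 3 is estimated at 10000 nM, with an expected range from 3000 nM to 25000 nM.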

Compound 3, half-maximal inhibitory concentration: 11700 nM
Beside the measured number, compound 3's estimate is 1.2-fold (0.07 log units) below it, and the stated range covers the measured number.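

In this assay, the swap at the thiocarbonyl carbon now has a measured size, since 5-methoxy-2,3-dihydro-1H-indol-1-yl gives a 9.1-fold higher number from compound 1 to compound 3 (0.96 log units; beyond the scatter). The earlier loss had no such size, as compound 2 reads only as a limit of the assay and not a number: the limit of > 20000 nM in this assay, at which 1 of the 3 values shown sits. Methoxy in place of bromo gives an at least 1.7-fold lower number from compound 2 to compound 3 (0.23 log units; that floor lies within the scatter), so these two groups cannot be put in order.

The compounds shown do not separate the effect of the methoxy group from that of the two-ring group carrying it, which plain 2,3-dihydro-1H-indol-1-yl would address. Nor do they show whether the second nitrogen of 4-methylpiperazin-1-yl matters, which piperidin-1-yl or morpholin-4-yl on the same carbon would test.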